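The compounds below may be only part of what the source reports. "The series", "measured", "known", "first", "only" and "open" are said of these compounds alone.

The series of aryl sulfones under study includes compound 1 `O=S(=O)(c1ccc(F)cc1)c1cnc2cc(Cl)c(F)cc2c1-c1ccc(Cl)cc1`, compound 2 `N#Cc1ccc2ncc(S(=O)(=O)c3ccc(F)cc3)c(-c3ccc(Cl)cc3)c2c1` and compound 3 `COc1cccc(-c2c(S(=O)(=O)c3cccc(C#N)c3)cnc3cc(F)ccc23)c1`, all examined in an ADME assay on microsomes from liver (Homo sapiens) for metabolic stability, tested at 2.5 uM; on this read-out lower numbers stand for slow clearance and higher numbers for fast clearance. Compound 1 gives 0.01 mL/min in this assay, and compound 2 gives 0.01 mL/min, level with compound 1 at the digits recorded; together the two stand as the lowest of the three numbers, with no change between them beyond the scatter. Compound 3, by contrast, gives 1.83 mL/min, which stands far higher than compound 2 and beyond the scatter.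

The account now turns to compound 4 `O=S(=O)(c1ccc(F)cc1)c1cnc2ccc(F)cc2c1-c1ccc(Cl)cc1`, which has not yet been measured in this assay. Compound 4 differs from compound 2 in a single respect: fluoro in place of cyano on an aromatic carbon. Going by the values given here, no measured pair in the set carries this exact change, so the size of its effect is not known from the data.

Given that compound 2 gives 0.01 mL/min and compound 1, which also carries fluoro on its fused ring system, gives 0.01 mL/min, compound 4 is expected to remain among the slowly cleared members, with an estimated step of a 3.0-fold higher number from compound 2 to compound 4 (0.48 log units; beyond the scatter) that may be small or none beyond the scatter. Compound 4 is therefore estimated at 0.03 mL/min, within a range from 0.01 mL/min to 0.15 mL/min.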

Compound 4, intrinsic clearance in a liver preparation (reported as CLH), per the amount of preparation that the assay uses: 0.12 mL/min
Compound 4: middle estimate off by 4.0-fold (0.60 log units), on the low side, and the stated range covers the measured number.
By their numbers in this assay, from the lowest: compounds 1 and 2 (each within the scatter of the next); then compound 4; then compound 3.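

The fused ring that carries the cyano of compound 2 proved not to be indifferent to what stands on it: in this assay, fluoro in place of cyano at this carbon, meta to a fused ring and para to a fused ring, gave a 12-fold higher number from compound 2 to compound 4 (1.08 log units; beyond the scatter) and so a large step beyond the scatter. Until now the set held only the level numbers of compound 1 and compound 2, which could have suggested that slow clearance came with the shared core whatever its substituents. A second single change points the same way, since hydrogen in place of chloro on an aromatic carbon gave a 12-fold higher number from compound 1 to compound 4 (1.08 log units; beyond the scatter), so that compound 4 loses the very low number by either route while keeping its sulfone and its chlorophenyl group.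

Going by these compounds, it remains open whether the low number of compound 2 is particular to cyano at this carbon, or whether a carboxylic acid, a primary amide or an amine placed there would stay level with compound 2 or move towards compound 4. Nothing available here explains why either step is as large as it is.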